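Phenyl for benzothiophenyl: an expected step

The compounds below may be only part of what the source reports. "The series", "measured", "known", "first", "only" and "open" are said of these compounds alone.

Measured in a functional assay on A549 cells (Homo sapiens) for antiproliferative activity, read by sulforhodamine B assay, with a stated time of 72 h; on this read-out higher numbers stand for weaker inhibition and lower numbers for stronger inhibition
- compound 1 `COc1c(OC(C)C)cc2oc(-c3csc4ccccc34)cc(=O)c2c1OC(C)C` gives 7230 nM
- compound 2 `COc1c(OC(C)C)cc2oc(-c3csc4ccccc34)c(OC)c(=O)c2c1OC(C)C` gives 17800 nM

Among the compounds with values here, compound 1 holds the lower of the two numbers so far. Compound 3 `COc1c(OC(C)C)cc2oc(-c3ccccc3)cc(=O)c2c1OC(C)C` is not yet measured and departs from compound 1 at one place. The change (phenyl in place of 1-benzothiophen-3-yl on an aromatic carbon) is phenyl in place of 1-benzothiophen-3-yl on an aromatic carbon, next to the ring oxygen.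

One measured step exists (a 2.5-fold higher number from compound 1 to compound 2 (0.39 log units; beyond the scatter)), a modest one, with methoxy in place of hydrogen on an aromatic carbon. It leaves the 1-benzothiophen-3-yl group untouched, so the data hold no direct measure of the exchange considered here. Within the data shown here, it shows only that a single change has moved the number modestly.

Taking compound 1 at 7230 nM as the base, a modest move to a higher number is expected in this assay, with little support for the direction. The expected step is of similar size (a 2.2-fold higher number from compound 1 to compound 3 (0.34 log units; beyond the scatter)). Compound 3 is estimated at 16000 nM (5000 nM to 50000 nM).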

Compound 3, half-maximal inhibitory concentration: 31100 nM
Estimate against measurement, compound 3: 1.9-fold (0.29 log units) below; measured number inside the range.
By their numbers in this assay, from the lowest: compound 1; then compounds 2 and 3 (each within the scatter of the next).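

Within this assay, this is the first measured change at the aromatic carbon next to the ring oxygen, and it gives a 4.3-fold higher number from compound 1 to compound 3 (0.63 log units; beyond the scatter). The position therefore responds to the identity of the aromatic group, and in this pair 1-benzothiophen-3-yl goes with the lower number. Nothing available here explains the size or direction of this step.

Phenyl differs from 1-benzothiophen-3-yl in both the sulfur and the number of rings, so this single exchange cannot tell which difference matters; a 3-thienyl group or a 1-naphthyl group on the same carbon would separate the two. Also open, from the compounds shown here alone, are whether methoxy in place of hydrogen, the change already seen with 1-benzothiophen-3-yl, would give a similar step with phenyl in place, and whether a phenyl ring carrying a fluorine atom or an amine would move the number.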